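Swapping a ring substituent in a dog half-life series

The source may hold more compounds than are shown below. What is called first, only, known or untested is meant among the compounds shown, and "the series" means these compounds.

Compound 1 `C[C@@H](NC(=O)C1(NC(=O)c2ccc(Br)nc2)CC1)c1ccc(-n2nc(Cl)c3ccccc32)cc1F`: 7.1 h
Compound 2 `C[C@@H](NC(=O)C1(NC(=O)c2cncc(Cl)n2)CC1)c1ccc(-n2nc(Cl)c3ccccc32)cc1F`: 15.1 h
Compound 3 `C[C@@H](NC(=O)C1(NC(=O)c2cncc(Cl)c2)CC1)c1ccc(-n2nc(Cl)c3ccccc32)cc1F`: 6 h

Three compounds sharing one core were examined in an in vivo ADME assay on the whole organism (strain Mongrel) for metabolic stability, with Canis familiaris (Canis lupus familiaris) as the target; a higher number here means that the compound lasts longer, a lower number that the compound disappears faster. Compound 3 sits at the low end of the three numbers: against compound 1 the gap is a 1.2-fold lower number from compound 1 to compound 3 (0.07 log units; within the scatter), which means the two cannot be told apart, while against compound 2 the step of a 2.5-fold lower number from compound 2 to compound 3 (0.40 log units; beyond the scatter) is a real one. Among the compounds with values here, the only step that clearly moved this assay in the set is a 2.1-fold higher number from compound 1 to compound 2 (0.33 log units; beyond the scatter).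

Compound 4 `COc1cncc(C(=O)NC2(C(=O)N[C@H](C)c3ccc(-n4nc(Cl)c5ccccc54)cc3F)CC2)c1` differs from compound 3 in one place: methoxy in place of chloro on an aromatic carbon. Within the data shown here, none of the measured steps tests this kind of change; all three of them swap one heteroaryl ring for another on the same carbonyl carbon, and the one pair that kept closely related rings, compound 1 and compound 3, gave a gap within the scatter. The replacement of a chloro by a methoxy on the same pyridine ring is therefore without precedent here, and the expectation is no step beyond the scatter in this assay, with the step from compound 3 to compound 4 estimated as no change at the digits printed from compound 3 to compound 4 (within the scatter). Compound 4 is expected to give about 6 h, within a range of 3 h to 13 h.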

Compound 4, half-life: 2.3 h
The estimate for compound 4 lay 2.6-fold (0.42 log units) above the measured number; the whole stated range lies above it.
By their numbers in this assay, from the lowest: compound 4; then compounds 3 and 1 (each within the scatter of the next); then compound 2.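

Until this point, the steps in this assay had all exchanged one heteroaryl ring for another on the carbonyl carbon, whereas a 2.6-fold lower number from compound 3 to compound 4 (0.42 log units; beyond the scatter) shows that changing a single substituent on the pyridine ring, at the aromatic carbon two atoms from the ring nitrogen, is enough to move the number beyond the scatter. Compound 4 now stands lowest of the four, with a 3.1-fold lower number from compound 1 to compound 4 (0.49 log units; beyond the scatter) and a 6.6-fold lower number from compound 2 to compound 4 (0.82 log units; beyond the scatter), both also beyond the scatter, so the 5-methoxypyridin-3-yl group is separated from each of the other three rings on the carbonyl carbon. No measurement at hand accounts for this fall in half-life.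

The compounds shown cannot say whether the oxygen of the methoxy or the departure of the chloro matters more; a methyl, a hydroxyl or an ethoxy at the same carbon would help to separate the two. From the compounds shown here alone, it also remains open whether a methoxy would have a comparable effect on the 6-chloropyrazin-2-yl ring of compound 2, which has the longest half-life in the set.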